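The source may hold more compounds than are shown below. What is called first, only, known or untested is meant among the compounds shown, and "the series" means these compounds.

Working notes on the series around compound 1 `Cn1ccnc1[C@@H](CC(=O)O)c1ccc(OCc2cccc(-c3ccccc3S(C)(=O)=O)c2)cc1`. Compound 1 carries a 2-(methylsulfonyl)phenyl ring at the end of the shared core. In an assay on CHO cells for agonist activity at Free fatty acid receptor 1 (Homo sapiens), read by luminescence, with a stated time of 20 s, in the presence of a further agent that is not named here (a lower number here means that less compound is needed, a higher number that more compound is needed for the effect), compound 1 gives "not determined" (no result reported), so there is no number for where it stands. The measured members are compound 2 `Cc1ccc(F)cc1-c1cccc(COc2ccc([C@H](CC(=O)O)c3nccn3C)cc2)c1`, which in this assay gives 42000 nM, and compound 3 `Cn1ccnc1[C@@H](CC(=O)O)c1ccc(OCc2cccc(-c3ccccc3Cl)c2)cc1`, which in this assay gives 56000 nM. Among the measured compounds shown here, the one step available, a 1.3-fold higher number from compound 2 to compound 3 (0.12 log units; within the scatter), shows that swapping the terminal ring substituents in this pair did not move the number beyond the scatter.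

Compound 4 `Cc1cc(F)ccc1-c1cccc(COc2ccc([C@H](CC(=O)O)c3nccn3C)cc2)c1` is the unmeasured member. Its difference from compound 1 is 4-fluoro-2-methylphenyl in place of 2-(methylsulfonyl)phenyl on an aromatic carbon. For the measured compounds named here, since compound 1 has no value, no step from it can be drawn, and the expectation for compound 4 rests on compound 2 and compound 3 alone. Compound 4 and compound 2 differ only in that compound 4 carries 4-fluoro-2-methylphenyl where compound 2 carries 5-fluoro-2-methylphenyl, and the step from compound 2 to compound 3 was within the scatter, so no shift beyond the scatter from those two values is expected. Compound 4 is therefore estimated to give 45000 nM in this assay, with an expected range from 18000 nM to 110000 nM.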

Compound 4, half-maximal effective concentration: 21000 nM
Estimate against measurement, compound 4: 2.1-fold (0.33 log units) above; the measured number falls inside the stated range.
By their numbers in this assay, from the lowest: compounds 4, 2 and 3 (each within the scatter of the next, the first and the last beyond it).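

In this assay, among the compounds shown here, the series now shows a 2.7-fold lower number from compound 3 to compound 4 (0.43 log units; beyond the scatter), the only step so far that lies beyond the scatter, so the substituents on this terminal ring can shift the number, though only modestly. The other new reading is a 2.0-fold lower number from compound 2 to compound 4 (0.30 log units; within the scatter), so 4-fluoro-2-methylphenyl and 5-fluoro-2-methylphenyl cannot be told apart at this position, and 4-fluoro-2-methylphenyl is separated only from the 2-chlorophenyl of compound 3. Nothing at hand gives a measured basis for either step.

For the compounds shown here, compound 1 has no number, so no step from it can be read, and the standing of 2-(methylsulfonyl)phenyl relative to the other terminal rings remains open. It also remains open whether an amine or a nitrile on this ring would move the number further than the steps seen among these halogen- and methyl-bearing rings.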